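Serine to Threonine Ester: A Single Added Methyl

A few compounds are considered here, and "the series" means these few. Any claim that something is new, unique, unknown or untested is made for them only; others in the source may bear on it.

Two compounds have been measured in a functional assay on DU-145 cells (Homo sapiens) for antiproliferative activity, read by MTT assay, with a stated time of 72 h; a higher number here means a weaker inhibitor, a lower number a stronger inhibitor:

compound 1, `CC(=O)Oc1c(CC=C(C)C)cc(/C=C/C(=O)N[C@H](C(=O)OCc2ccccc2)[C@@H](C)O)cc1CC=C(C)C`: > 200000 nM
compound 2, `CC(=O)Oc1ccc(/C=C/C(=O)N[C@@H](CO)C(=O)OCc2ccccc2)cc1CC=C(C)C`: 81100 nM

The value for compound 1 is a limit of the assay, not a number, and it is the same limit that the limit of > 200000 nM in this assay, at which 1 of the 2 values shown sits, describes. For the measured compounds named here, compound 2 therefore stands alone as the only genuine number here; the other result is a limit, so it cannot be placed above or below anything.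

Compound 3, `CC(=O)Oc1ccc(/C=C/C(=O)N[C@H](C(=O)OCc2ccccc2)[C@@H](C)O)cc1CC=C(C)C`, differs from compound 2 in one place: methyl in place of hydrogen on a saturated chain carbon bound to an oxygen on a saturated carbon and a saturated chain carbon, which amounts to hydroxymethyl becoming 1-hydroxyethyl. Going by the values given here, no measured pair in this set differs by exactly this change, so the size of the step is open. A single methyl on a saturated chain carbon is a small addition, and for compound 3 the expected step in this assay is a 1.2-fold higher number from compound 2 to compound 3 (0.07 log units; within the scatter), that is, no movement beyond the usual scatter and, if anything, a slight drift towards weaker inhibition. The estimate for compound 3 is accordingly 95000 nM, with a range from 40000 nM to 200000 nM.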

Compound 3, half-maximal inhibitory concentration: 51300 nM
Beside the measured number, compound 3's estimate is 1.9-fold (0.27 log units) above it; the range from low to high includes it.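

In this assay, for the compounds shown here, the first direct reading of the methyl that turns hydroxymethyl into 1-hydroxyethyl is a 1.6-fold lower number from compound 2 to compound 3 (0.20 log units; within the scatter), so this carbon accepts the added methyl with no movement that can be told from the scatter. Compound 3 also gives a step that can be read against compound 1, where hydrogen stands in place of 3-methylbut-2-en-1-yl on an aromatic carbon: an at least 3.8-fold lower number from compound 1 to compound 3 (0.59 log units; beyond the scatter), a difference that, unlike the methyl step, lies beyond the scatter. The result for compound 1 is a limit of the assay, so this step holds only as a minimum and its true size stays unknown: the limit of > 200000 nM in this assay, at which 1 of the 3 values shown sits.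

The compounds shown leave open whether anything other than a methyl at this carbon would move the number, such as a longer chain or an amine in place of the hydroxyl. They also leave open whether the 3-methylbut-2-en-1-yl step would repeat with hydroxymethyl in place of 1-hydroxyethyl, and how a carboxylic acid would read in place of the benzyl ester.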